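Thiophene for methylphenyl on the benzylic amine arm

The source may report more compounds than this note shows. Statements on the series, on what has been measured and on what is new or still open speak of the compounds shown alone.

Measured compounds:
compound 1 `CC(C)c1ccccc1-c1nc(NCc2ccc(-c3cccnc3)cc2)c2nc[nH]c2n1` — 120 nM
compound 2 `Cc1cccc(CNc2nc(-c3ccccc3C(C)C)ncc2C)c1` — 130 nM

In an assay on a protein complex for inhibition of ubiquitin carboxyl-terminal hydrolase 1/WD repeat-containing protein 48 (Homo sapiens), read by fluorescence (a lower number here means a stronger inhibitor, a higher number a weaker inhibitor), compound 1 gives 120 nM and compound 2 gives 130 nM. Within the data shown here, compound 2 holds the higher of the two numbers, but the gap to compound 1 lies within the scatter, so the two compounds are not told apart in this assay; no step between them is counted, and nothing is said here about which is the stronger inhibitor.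

Compound 3 `Cc1cnc(-c2ccccc2C(C)C)nc1NCc1cccs1` has not yet been measured. It differs from compound 2 in one place: thiophen-2-yl in place of 3-methylphenyl on a saturated chain carbon bound to a nitrogen on an aromatic ring. The rest of the molecule, including the shared core and the group bound to it, is unchanged.

Among the measured compounds shown here, no measured pair shows this kind of change, so the size of the step rests on the change alone. A five-membered aromatic ring with a sulfur replaces a six-membered aromatic ring of carbon only; a modest loss is expected, most likely beyond the scatter but not large. Compound 3 is estimated at 260 nM in this assay, with a range from 110 nM to 650 nM. The step expected from compound 2 to compound 3 is a 2.0-fold higher number from compound 2 to compound 3 (0.30 log units; within the scatter).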

Compound 3, half-maximal inhibitory concentration: 270 nM
Compound 3: middle estimate off by 1.0-fold (0.02 log units), on the low side; measured number inside the range.
By their numbers in this assay, from the lowest: compounds 1 and 2 (each within the scatter of the next); then compound 3.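

In this assay, among these compounds, the change at this position gives the first readable step: thiophen-2-yl in place of 3-methylphenyl on a saturated chain carbon bound to a nitrogen on an aromatic ring gives a 2.1-fold higher number from compound 2 to compound 3 (0.32 log units; beyond the scatter). Among the compounds shown here, compounds 1 and 2 differ in more than one place and could not isolate this position, so this pair is the first to show that the number responds to the group held there, while the step remains modest and compound 3 still reads 270 nM. No measurement at hand gives a reason for the step.

From the compounds shown here alone, this single pair changes the ring type, the ring size and the methyl group together, so it remains open which of these carries the step; a plain phenyl, a thiophen-3-yl or a furan-2-yl on the same carbon would begin to separate them. Also open, going by these compounds, is whether the same exchange would give a step of similar size on the core of compound 1, or with a pyridin-3-yl or an amine on the ring held at this position.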